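Phenyl for tert-butyl on the benzyl arm: cytotoxicity outlook

The source may report more compounds than this note shows. Statements on the series, on what has been measured and on what is new or still open speak of the compounds shown alone.

Compound 1 `CCc1ccc2[nH]c(=O)c(CN(Cc3ccc(F)cc3)Cc3ccc(C(C)(C)C)cc3)cc2c1` has only a limit in a toxicity assay on MDCK cells (Canis lupus familiaris) for cytotoxicity, read by crystal violet staining, with a stated time of 48 h; a higher number here means that more compound is tolerated, a lower number that less compound is tolerated: compound 1 gives > 33000 nM, a limit of the assay rather than a number. Compound 2 `CCCc1ccc2[nH]c(=O)c(CN(Cc3ccc(F)cc3)Cc3ccc(C(C)(C)C)cc3)cc2c1` gives 8400 nM, and compound 3 `CC(C)c1ccc2[nH]c(=O)c(CN(Cc3ccc(F)cc3)Cc3ccc(C(C)(C)C)cc3)cc2c1` gives 7900 nM. All measured steps change the alkyl group on the core: an at least 3.9-fold lower number from compound 1 to compound 2 (0.59 log units; beyond the scatter), an at least 4.1-fold lower number from compound 1 to compound 3 (0.62 log units; beyond the scatter) and a 1.1-fold lower number from compound 2 to compound 3 (0.03 log units; within the scatter). Compound 4 `CCc1ccc2[nH]c(=O)c(CN(Cc3ccc(F)cc3)Cc3ccc(-c4ccccc4)cc3)cc2c1` differs from compound 1 elsewhere: phenyl in place of tert-butyl on an aromatic carbon. Among the measured compounds shown here, no measured step touches this position, so those steps give no direct guide, and the only anchor is the limit of > 33000 nM in this assay, at which 1 of the 3 values shown sits. Compound 4 is therefore expected to sit near compound 1, an expected step of an at least 1.3-fold lower number from compound 1 to compound 4 (0.12 log units; that floor lies within the scatter) with wide uncertainty. Compound 4 is estimated at 25000 nM, ranging from 8000 nM to 60000 nM.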

Compound 4, half-maximal cytotoxic concentration: > 5000 nM
Compound 4: no number, only a limit; the forecaster's own chance of this, stated with the estimate: 45%; the middle value does not contradict the limit.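

In this assay compound 4 gives > 5000 nM, a limit. Among the compounds shown here, compound 1 gives > 33000 nM, also a limit, so no step between these two compounds can be read. From the compounds shown here alone, whether phenyl in place of tert-butyl changes the tolerated concentration at all remains open.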